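A few compounds are considered here, and "the series" means these few. Any claim that something is new, unique, unknown or untested is made for them only; others in the source may bear on it.

Measured compounds:
Compound 1 `CCCCCCNC(=O)Nc1ccc(/C(N)=N/O)cc1` — > 1000000 nM (a limit)
Compound 2 `CCCCNCCC(=O)Nc1ccc(/C(N)=N/O)cc1` — 881000 nM
Compound 3 `CCCCNC(=O)Nc1ccc(/C(N)=N/O)cc1` — > 1000000 nM (a limit)

Of the compounds shown here, three have been measured in a functional assay on A549 cells (Homo sapiens) for antiproliferative activity, read by WST assay, with a stated time of 72 h; a lower number here means that less compound is needed, a higher number that more compound is needed for the effect. Compound 1 gives > 1000000 nM, which is a limit of the assay and not a number. Compound 3 likewise gives > 1000000 nM in this assay, again a limit. Going by the values given here, compound 2 gives 881000 nM in this assay, the only number among the three. The change from compound 3 to compound 1 is ethyl in place of hydrogen on a saturated chain carbon, four bonds along the chain from an amide-type nitrogen. The step that the two limits leave unreadable from compound 3 to compound 1 cannot be sized because both compounds sit at the limit of > 1000000 nM in this assay, at which 2 of the 3 values shown sit. The difference between the core of compound 2 and the core of compound 3 is not broken down here.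

Compound 4 `CCCCCCNCCC(=O)Nc1ccc(/C(N)=N/O)cc1` has not yet been measured in this assay. It differs from compound 2 by ethyl in place of hydrogen on a saturated chain carbon, four bonds along the chain from an amine nitrogen. This is the same kind of change as that from compound 3 to compound 1, but the place differs: there the saturated chain carbon lies four bonds along the chain from an amide-type nitrogen, here it lies four bonds along the chain from an amine nitrogen. Among the compounds with values here, the expectation for compound 4 rests on compound 2, whose 881000 nM is the only number seen, and on the unreadable step that the two limits leave unreadable from compound 3 to compound 1, which gives no sign that the added ethyl moved anything. The step from compound 2 to compound 4 is therefore expected to be a 1.3-fold lower number from compound 2 to compound 4 (0.10 log units; within the scatter). Compound 4 is estimated at 700000 nM, with a range from 200000 nM to 1500000 nM.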

Compound 4, half-maximal effective concentration: > 1000000 nM
Compound 4: a limit, no number (the forecaster's own chance of this, stated with the estimate: 40%); at least 1.4-fold (0.15 log units) between middle value and limit.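

In this assay compound 4 gives > 1000000 nM, which is a limit of the assay and not a number. On the core of compound 2, the ethyl in place of hydrogen therefore yields only an at least 1.1-fold higher number from compound 2 to compound 4 (0.05 log units; that floor lies within the scatter), so this series does not show that the change moved the value on this core, and it does not show that the change left the value alone. The same change on the core of compound 3 cannot be read in the step to compound 1, so neither core gives the change a size and the account can neither confirm nor rule out that it carries from one core to the other, since almost every compound shown stops at the same ceiling: the limit of > 1000000 nM in this assay, at which 3 of the 4 values shown sit.

On these data alone, it remains open whether a longer chain, a shorter chain or a terminal carboxylic acid in place of the ethyl would give a number clear of that limit on the core of compound 2. As far as these compounds go, it also remains open whether any change on either core would give a step large enough to compare between the two.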